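The source may report more compounds than this note shows. Statements on the series, on what has been measured and on what is new or still open speak of the compounds shown alone.

Three compounds of a shared core, each with a hydroxamic acid or a related amide at one end and a five-membered ring carrying two aryl groups at the other, have been tested in an assay on Sf9 cells for inhibition of protein deacetylase HDAC6 (Homo sapiens), read by fluorescence, with a stated time of 40 min, tested at 100 nM; on this read-out lower numbers stand for less inhibition and higher numbers for more inhibition at the one concentration tested (going by the name of the read-out). Compound 1, `O=C(NO)c1ccc(NCc2nc(-c3ccc(Br)cc3)nn2-c2ccccc2)cc1`, gives 54.7%. Compound 2, `Cc1cccc(-n2nc(-c3ccccc3)nc2CNc2ccc(C(=O)NO)cc2)c1`, gives 66%. Compound 3, `Nc1ccccc1NC(=O)c1ccc(NCc2nc(-c3ccccc3)nn2-c2ccccc2)cc1`, which carries an aminophenyl amide in place of the hydroxamic acid, gives 5%. Compound 2 thus stands highest of the three, and its lead over compound 1 and over compound 3 lies beyond the usual scatter of this assay, so its inhibition in this assay is the highest of the measured set.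

Compound 4, `O=C(NO)c1ccc(NCc2nc(-c3ccccc3)nn2-c2ccc(Br)cc2)cc1`, keeps the hydroxamic acid and the two aryl groups on the five-membered ring but changes one of them: 4-bromophenyl in place of 3-methylphenyl on an aromatic nitrogen. The only measured hint of how a bromine on an aryl group behaves here is compound 1, which bears a bromophenyl on a ring carbon and sits somewhat below compound 2. Among the compounds with values here, no measured pair isolates the change on the ring nitrogen itself.

The step from compound 2 to compound 4 is expected to be small, a number 9 percentage points lower from compound 2 to compound 4 (within the scatter), a modest decrease that may not exceed the scatter. Compound 4 is therefore estimated at 57% in this assay, within a range of 35% to 75%.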

Compound 4, a percentage reported as inhibition, at one concentration (the size of the read-out at that concentration, not a potency): 65.9%
Beside the measured number, compound 4's estimate is 8.9 percentage points below it; the measured number falls inside the stated range.
By their numbers in this assay, from the lowest: compound 3; then compound 1; then compounds 4 and 2 (each within the scatter of the next).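

In this assay, placing 4-bromophenyl instead of 3-methylphenyl on the aromatic nitrogen gives a number 0.1 percentage points lower from compound 2 to compound 4 (within the scatter), so the two groups cannot be told apart at this position. Within the data shown here, this is the first direct look at that position, since the earlier compounds offered no pair that differed there alone, and it shows that the hydroxamic acid series can carry either aryl group on this nitrogen with no change beyond the scatter. Nothing available explains this result, and no further data bear on why the two groups read alike.

The swap changes both the substituent on the aryl ring and where it sits, so the step cannot say what either change would do alone, and two effects that offset each other cannot be ruled out. On these data alone, it also remains open whether this position would accept a very different group, such as an aryl ring carrying an amine or a carboxylic acid, or a longer alkyl chain in place of the aryl ring, and whether the match seen at this one concentration would hold across a range of concentrations.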